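Swapping a nitrophenyl group for a methylphenyl group

A few compounds are considered here, and "the series" means these few. Any claim that something is new, unique, unknown or untested is made for them only; others in the source may bear on it.

Measured in a functional assay on HCT-116 cells (Homo sapiens) for inhibition, read by MTT assay, with a stated time of 2 days; on this read-out higher numbers stand for weaker inhibition of growth and lower numbers for stronger inhibition of growth:
compound 1 `Nc1ccccc1NC(=O)CCCNCC(=O)Nc1cccc([N+](=O)[O-])c1`: 900 nM
compound 2 `Nc1ccccc1NC(=O)c1ccc(NCC(=O)Nc2ccc([N+](=O)[O-])cc2)cc1`: 600 nM
compound 3 `Nc1ccccc1NC(=O)c1ccc(NCC(=O)Nc2cccc([N+](=O)[O-])c2)cc1`: 1100 nM

Compound 3, at 1100 nM, lies within the usual scatter of both compound 1 and compound 2, so these numbers do not set it apart from either. Compound 4 `Cc1ccc(NC(=O)CNc2ccc(C(=O)Nc3ccccc3N)cc2)cc1` has not yet been measured. It differs from compound 3 by a single change: 4-methylphenyl in place of 3-nitrophenyl on an amide-type nitrogen. In words, this is 4-methylphenyl in place of 3-nitrophenyl on an amide-type nitrogen.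

Among the measured compounds shown here, only one measured step involves this same place, 3-nitrophenyl in place of 4-nitrophenyl, and it stays within the scatter: a 1.8-fold higher number from compound 2 to compound 3 (0.26 log units; within the scatter). That step only compares two nitrophenyl groups. For the measured compounds named here, no measured compound carries anything else at this place, so the evidence for the new swap is thin. Given a 1.8-fold higher number from compound 2 to compound 3 (0.26 log units; within the scatter), no step beyond the scatter is expected in this assay, in either direction. The expected step is a 1.2-fold lower number from compound 3 to compound 4 (0.09 log units; within the scatter). The estimate for compound 4 is 900 nM, with an expected range from 350 nM to 2500 nM.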

Compound 4, concentration for 50% growth inhibition: 12600 nM
Compound 4: the middle estimate sits 14-fold (1.15 log units) below what was measured, and the stated range ends below it.
By their numbers in this assay, from the lowest: compounds 2, 1 and 3 (each within the scatter of the next); then compound 4.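

In this assay, the group on this amide-type nitrogen turns out to matter a great deal, which the two nitrophenyl compounds could not show because moving the nitro group gave only a 1.8-fold higher number from compound 2 to compound 3 (0.26 log units; within the scatter). Replacing 3-nitrophenyl with 4-methylphenyl gives an 11-fold higher number from compound 3 to compound 4 (1.06 log units; beyond the scatter), a clear loss of growth inhibition, and the comparison that keeps the group's printed 4-position, methyl in place of nitro on an aromatic carbon, gives an even larger a 21-fold higher number from compound 2 to compound 4 (1.32 log units; beyond the scatter), so among these compounds the change of nitro to methyl counts for far more than the place of the nitro group. No supporting measurement is available to explain this drop.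

The compounds shown leave open whether the nitro group helps or the methyl group harms, a question that a plain phenyl, a 4-chlorophenyl or a 4-cyanophenyl at the same place could begin to answer. They also leave open whether 3-methylphenyl would match 4-methylphenyl, and whether the same swap would cost as much on the chain-linked core of compound 1.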